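The source may hold more compounds than are shown below. What is called first, only, known or untested is meant among the compounds shown, and "the series" means these compounds.

Measured so far:
compound 1, `COc1cc(OC)c(C(=O)/C=C/c2ccc(N3CCNCC3)cc2)c(O)c1CC=C(C)C`: 57800 nM
compound 2, `COc1cc(OC)c(C(=O)/C=C/c2ccc(F)cc2)c(O)c1CC=C(C)C`: 53700 nM

Compound 1 gives the highest of the two numbers in an ADME assay on MCF7-DOX cells (Homo sapiens) for cytotoxicity, read by MTT assay, with a stated time of 48 h; a higher number here means a weaker inhibitor, a lower number a stronger inhibitor; its nearest neighbour is compound 2, and the step of a 1.1-fold lower number from compound 1 to compound 2 (0.03 log units; within the scatter) lies within the scatter, so the two values are not distinguished by this measurement.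

Compound 3, `COc1cc(OC)c(C(=O)/C=C/c2ccc(N3CCN(C(=O)OC(C)(C)C)CC3)cc2)c(O)c1CC=C(C)C`, differs from compound 1 in one place: tert-butoxycarbonyl in place of hydrogen on an amine nitrogen in a ring.

Among the measured compounds shown here, only the single step from compound 1 to compound 2 is available, and it changes a different part of the molecule, the aromatic carbon rather than the amine nitrogen in the ring. For the measured compounds named here, no measured step bears directly on a tert-butoxycarbonyl in place of hydrogen on an amine nitrogen in a ring. Given that both measured compounds sit at nearly the same number in this assay, compound 3 is expected to stay close to compound 1, with the step of a 1.1-fold lower number from compound 1 to compound 3 (0.02 log units; within the scatter) expected to fall within the scatter. Compound 3 is therefore estimated at 55000 nM, with a range from 20000 nM to 150000 nM.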

Compound 3, half-maximal inhibitory concentration: > 100000 nM
Compound 3 was reported as a limit; the forecaster's own chance of this, stated with the estimate: 20%; at least 1.8-fold (0.25 log units) between middle value and limit.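

In this assay compound 3 gives > 100000 nM, which is a limit and not a number. Among the compounds shown here, this is the first reading at the amine nitrogen of the ring, and the step, an at least 1.7-fold higher number from compound 1 to compound 3 (0.23 log units; that floor lies within the scatter), shows that tert-butoxycarbonyl in place of hydrogen there does not bring the number down, although the floor of that step does not separate the change from the scatter. How far the number actually moves cannot be read, because compound 3 sits at the limit: the limit of > 100000 nM in this assay, at which 1 of the 3 values shown sits.

The compounds shown leave open whether a methyl or an acetyl group on that ring nitrogen would stay close to compound 1. They also do not tell whether the carbonyl or the tert-butyl part of the new group matters here.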